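The compounds below may be only part of what the source reports. "The series", "measured", "known", "first", "only" and "open" are said of these compounds alone.

Of the compounds shown here, three have been measured so far. Compound 1 `Cc1ccc(NC(=O)CCN(Cc2ccc(C(=O)NO)cc2)C(=O)c2cc(C)cc(C)c2)cc1`, compound 2 `Cc1cc(C)cc(C(=O)N(CCC(=O)NCc2ccccc2)Cc2ccc(C(=O)NO)cc2)c1` and compound 3 `COc1cc(OC)cc(C(=O)N(CCC(=O)NCc2ccccc2)Cc2ccc(C(=O)NO)cc2)c1` share a common core and differ from one another at two places. In an assay on Sf9 cells for inhibition of protein deacetylase HDAC6 (Homo sapiens), read by fluorescence, with stated times of 90 min and 30 min (a higher number here means a weaker inhibitor, a lower number a stronger inhibitor), compound 1 gives 31.1 nM, compound 2 gives 20.5 nM and compound 3 gives 26 nM. Compound 3 stands second highest of these three numbers, yet all three lie within the scatter of one another, so none of them can be called stronger or weaker than the rest. The step of a 1.5-fold lower number from compound 1 to compound 2 (0.18 log units; within the scatter) exchanged one group on an amide-type nitrogen; the step of a 1.3-fold higher number from compound 2 to compound 3 (0.10 log units; within the scatter) exchanged the aromatic group on a carbonyl carbon, the same place that changes now.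

Compound 4 `CN(C)c1ccc(C(=O)N(CCC(=O)NCc2ccccc2)Cc2ccc(C(=O)NO)cc2)cc1` differs from compound 3 by 4-(dimethylamino)phenyl in place of 3,5-dimethoxyphenyl on a carbonyl carbon. Of the measured steps, only the exchange on the carbonyl carbon bears on this change, and that step stayed within the scatter. In this assay the expected step is therefore no change at the digits printed from compound 3 to compound 4 (within the scatter), which is none beyond the scatter. Compound 4 is estimated at 26 nM, with a range from 12 nM to 55 nM.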

Compound 4, half-maximal inhibitory concentration: 14.8 nM
Estimate against measurement, compound 4: 1.8-fold (0.24 log units) above; measured number inside the range.
By their numbers in this assay, from the lowest: compounds 4, 2, 3 and 1 (each within the scatter of the next, the first and the last beyond it).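

At this place on the carbonyl carbon, 4-(dimethylamino)phenyl in place of 3,5-dimethoxyphenyl gives a 1.8-fold lower number from compound 3 to compound 4 (0.24 log units; within the scatter), and in place of 3,5-dimethylphenyl it gives a 1.4-fold lower number from compound 2 to compound 4 (0.14 log units; within the scatter) in this assay. The position has therefore now held a phenyl ring with one nitrogen-bearing group as well as phenyl rings with two methoxy or two methyl groups, and compounds 2, 3 and 4 all stay within the scatter of one another. Nothing measured here explains why these three groups read alike.

The compounds shown leave open how a bare phenyl ring would compare, so what any of these ring groups adds remains unknown. They also leave open whether this place would accept a phenyl ring bearing a carboxylic acid, or a saturated cyclohexyl group in place of the aromatic ring.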